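The source may hold more compounds than are shown below. What is called first, only, known or untested is meant among the compounds shown, and "the series" means these compounds.

Of the compounds shown here, three built on a shared core have been tested in a functional assay on the whole organism (strain ICR) for inhibition, with Mus musculus as the target, with a stated time of 16 h, at a dose of 10 mg/kg by the oral route; a lower number here means less inhibition, a higher number more inhibition at the dose given (going by the name of the read-out). Compound 1 `Cn1c(-c2ccccc2C(F)(F)F)nnc1C12CCC(CCS(=O)(=O)C(C)(C)C)(CC1)CC2` gives 10%, the lowest of the three numbers. Compound 2 `CCS(=O)(=O)CCC12CCC(c3nnc(-c4ccccc4C)n3C)(CC1)CC2` gives 30%, and compound 3 `CCS(=O)(=O)CCC12CCC(c3nnc(-c4ccccc4Br)n3C)(CC1)CC2` gives 65%. Among the compounds with values here, the only pair that differs in one place shows a step of a number 35 percentage points higher from compound 2 to compound 3 (beyond the scatter), a change on an aromatic carbon. Compound 4 `CC(C)S(=O)(=O)CCC12CCC(c3nnc(-c4ccccc4C(F)(F)F)n3C)(CC1)CC2` differs from compound 1 by hydrogen in place of methyl on a saturated chain carbon bound to two saturated chain carbons and a sulfonyl sulfur, a change on the saturated chain, far from the aromatic carbon. Within the data shown here, no measured step touches that place, so nothing here points to a shift in this assay beyond the scatter in either direction. Compound 4 is therefore expected to give about 15%, between 0% and 40%. That estimate means an expected step of a number 5 percentage points higher from compound 1 to compound 4 (within the scatter), within the scatter.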

Compound 4, a percentage reported as inhibition, in the whole organism at one dose (the size of the read-out at that dose, not a potency): 59%
For compound 4 the middle estimate is 44 percentage points below the measured one, and the stated range ends below it.
By their numbers in this assay, from the lowest: compound 1; then compound 2; then compounds 4 and 3 (each within the scatter of the next).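

Changing tert-butyl to isopropyl gives a number 49 percentage points higher from compound 1 to compound 4 (beyond the scatter), so the group on this saturated chain carbon bound to two saturated chain carbons and a sulfonyl sulfur matters in this whole-animal test. Losing one methyl, a single carbon with no ring or charge involved, is enough for a large step, as large in size as the earlier change on an aromatic carbon. Nothing available explains why this step occurs.

Still open, as far as these compounds go, is whether a cyclopropyl group or a longer chain on the sulfonyl would hold this gain. Also open, from the compounds shown here alone, is how a plain methyl there would compare with isopropyl.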